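The source may report more compounds than this note shows. Statements on the series, on what has been measured and on what is new or still open speak of the compounds shown alone.

Compound 2 `Cc1cccc(NC(=O)C(=O)Nc2ccc(OCC(=O)O)c(F)c2)c1` gives 36.3% in a functional assay on CHO cells for agonist activity at Free fatty acid receptor 1 (Homo sapiens), read by FLIPR, tested at 300 nM; on this read-out higher numbers stand for a stronger effect at the one concentration tested and lower numbers for a weaker effect; it stands with only one neighbour among the numbers shown, compound 1 `O=C(O)COc1ccc(NC(=O)C(=O)Nc2ccccc2)cc1F`, which gives 26.5%, and the step of a number 9.8 percentage points higher from compound 1 to compound 2 (within the scatter) lies within the scatter. Compound 3 `O=C(O)COc1ccc(NC(=O)C(=O)Nc2cccc(Cl)c2)cc1F` differs from compound 2 by chloro in place of methyl on an aromatic carbon. Among the compounds with values here, the only measured step bearing on a change at this aromatic carbon is the one from compound 1 to compound 2, and it stayed within the scatter, so no step beyond the scatter is expected in this assay. Compound 3 is therefore estimated at 34%, between 15% and 55%, a step of a number 2.3 percentage points lower from compound 2 to compound 3 (within the scatter).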

Compound 3, a percentage reported as activity, at one concentration (the size of the read-out at that concentration, not a potency): 33.7%
Estimate against measurement, compound 3: 0.3 percentage points above; measured number inside the range.
By their numbers in this assay, from the lowest: compounds 1, 3 and 2 (each within the scatter of the next).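

In this assay, within the data shown here, the change from methyl to chloro gives no step that can be told from the scatter, with a number 2.6 percentage points lower from compound 2 to compound 3 (within the scatter), and chloro in place of hydrogen gives none either, with a number 7.2 percentage points higher from compound 1 to compound 3 (within the scatter). Compound 1, compound 2 and compound 3 thus all stand within the scatter of one another, now with two different groups tried against hydrogen at this position. No measurement shown here bears on the reason for this. On these data alone, what remains open is whether a methoxy group, a trifluoromethyl group or an amine at this aromatic carbon would give a step beyond the scatter.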